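The source may report more compounds than this note shows. Statements on the series, on what has been measured and on what is new or still open speak of the compounds shown alone.

Of the compounds shown here, three built on one shared core have been tested in a functional assay on MGC-803 cells (Homo sapiens) for inhibition, read by sulforhodamine B assay; a higher number here means a weaker inhibitor, a lower number a stronger inhibitor. Compound 1 `O=C1C(Nc2ccc(Br)cc2)=CC(=O)c2c1nc1n2[C@H]2OC[C@@H](O)[C@H]2OC1` gives 2020 nM, compound 2 `CCc1ccc(NC2=CC(=O)c3c(nc4n3[C@H]3OC[C@@H](O)[C@H]3OC4)C2=O)cc1` gives 1110 nM, and compound 3 `O=C1C(Nc2ccc(C(F)(F)F)cc2)=CC(=O)c2c1nc1n2[C@H]2OC[C@@H](O)[C@H]2OC1` gives 1860 nM, the second highest of the three numbers and nearest to compound 1. Every measured step swaps a group on an aromatic carbon and stays within the scatter: a 1.8-fold lower number from compound 1 to compound 2 (0.26 log units; within the scatter), a 1.1-fold lower number from compound 1 to compound 3 (0.04 log units; within the scatter) and a 1.7-fold higher number from compound 2 to compound 3 (0.22 log units; within the scatter). Compound 4 `O=C1C(Nc2cccc(F)c2)=CC(=O)c2c1nc1n2[C@H]2OC[C@@H](O)[C@H]2OC1` differs from compound 3 by 3-fluorophenyl in place of 4-(trifluoromethyl)phenyl on an amine nitrogen. Going by the values given here, no measured step involves a 3-fluorophenyl group, so the three small steps among compounds 1, 2 and 3 bear only indirectly and point to no shift beyond the scatter. Compound 4 is therefore expected to give 1800 nM in this assay, within 900 nM to 3600 nM, that is a 1.0-fold lower number from compound 3 to compound 4 (0.01 log units; within the scatter).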

Compound 4, half-maximal inhibitory concentration: 1470 nM
Estimate against measurement, compound 4: 1.2-fold (0.09 log units) above; the range from low to high includes it.
By their numbers in this assay, from the lowest: compounds 2, 4, 3 and 1 (each within the scatter of the next).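

Moving to 3-fluorophenyl on the amine nitrogen in this assay stays within the scatter from 4-(trifluoromethyl)phenyl (a 1.3-fold lower number from compound 3 to compound 4 (0.10 log units; within the scatter)), from 4-ethylphenyl (a 1.3-fold higher number from compound 2 to compound 4 (0.12 log units; within the scatter)) and from 4-bromophenyl (a 1.4-fold lower number from compound 1 to compound 4 (0.14 log units; within the scatter)). Going by these compounds alone, the earlier compounds varied only groups carrying their substituent at the 4 of the phenyl ring, so compound 4 is the first to show that a 3-fluorophenyl group also leaves the number within the scatter of all three. No available evidence bears on this result. Still open, on these data alone, is whether a phenyl ring carrying an amine or a carboxylic acid, or a longer alkyl chain in place of the phenyl ring on this nitrogen, would shift the number beyond the scatter.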